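The source may report more compounds than this note shows. Statements on the series, on what has been measured and on what is new or still open speak of the compounds shown alone.

Of the compounds shown here, two built on the same core have been tested in a functional assay for inhibition, with a stated time of 30 h, tested at 100 ug/mL; on this read-out higher numbers stand for more inhibition at the one concentration tested (going by the name of the read-out) and lower numbers for less inhibition. Compound 1 `CCOc1cccc(C(CC)c2ccc(O)c(OC)c2)c1O` gives 97%. Compound 2 `CCC(c1ccc(O)c(OC)c1)c1ccc(O)cc1O` gives 97%, a figure level with that of compound 1 at the digits shown and within the usual scatter, so the two stand together near the top of the scale in this assay. Compound 3 `CCC(c1ccc(O)c(OC)c1)c1cccc(C(C)C)c1O` has not yet been measured. It differs from compound 1 in one place (isopropyl in place of ethoxy on an aromatic carbon). Going by the values given here, no measured pair shows what such a swap does here; the only guide is that both measured compounds give numbers near the top of the scale in this assay. The expected step is a number 7 percentage points lower from compound 1 to compound 3 (within the scatter), small or none beyond the scatter, and any real movement would more plausibly be downward, as the scale leaves little room above. Compound 3 is estimated to give 90%, within a range from 70% to 100%.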

Compound 3, a percentage reported as inhibition, at one concentration (the size of the read-out at that concentration, not a potency): 97%
The estimate for compound 3 lay 7 percentage points below the measured number; low and high end bracket the measured number.
By their numbers in this assay, from the lowest: compounds 1, 2 and 3 (each within the scatter of the next).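

Isopropyl in place of ethoxy on an aromatic carbon, ortho to a hydroxy group, brings no change at the digits printed from compound 1 to compound 3 (within the scatter) in this assay and thus gives the first direct reading at this position. On this read-out, at the one concentration tested, the ethoxy oxygen can be replaced by an all-carbon group with no loss beyond the scatter, so this position accepts at least this one change. No measurement at hand explains why the two groups give the same result.

All three compounds sit near the top of the scale at a single concentration, so a real difference in potency could stay hidden. As far as these compounds go, whether an amine, a carboxylic acid or a longer chain at this position would also hold the read-out remains open.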